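Compound 4: a step that starts from a limit

The source may report more compounds than this note shows. Statements on the series, on what has been measured and on what is new or still open speak of the compounds shown alone.

Of the compounds shown here, three sharing one core have been tested in an ADME assay on LLC-PK1 cells (Sus scrofa) for permeability, with a stated time of 3 h, tested at 1 uM; a lower number here means that the compound crosses the layer more slowly, a higher number that the compound crosses the layer faster. Within the data shown here, compound 1 (`O=C(O)CNC(=O)c1c(O)c2c(n(Cc3ccc(OC(F)(F)F)cc3)c1=O)COC2`) gives 5.2 10^-6 cm/s, the only true number so far. Compound 2 (`O=C(O)CNC(=O)c1c(O)c2c(n(Cc3ccc(F)cc3F)c1=O)COC2`) gives < 2.2 10^-6 cm/s, which is a limit of the assay and not a number. Going by these compounds, compound 3 (`O=C(O)CNC(=O)c1c(O)c2c(n(Cc3cnc(C(F)(F)F)s3)c1=O)COC2`) gives < 1.5 10^-6 cm/s, which is also only a limit, so its true standing in this assay is unknown.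

Compound 4 (`O=C(O)CNC(=O)c1c(O)c2c(n(Cc3nc4ccccc4o3)c1=O)COC2`) carries 1,3-benzoxazol-2-yl in place of 2-(trifluoromethyl)-1,3-thiazol-5-yl on a saturated chain carbon bound to an aromatic nitrogen.

Among the measured compounds shown here, the one measured step at this place is a step that the two limits leave unreadable from compound 2 to compound 3, so it offers no size to carry over. For the measured compounds named here, the only guide to an upper end is compound 1, at 5.2 10^-6 cm/s, and a value that high is not expected here. The expected change is an at least 1.2-fold higher number from compound 3 to compound 4 (0.07 log units; that floor lies within the scatter), a small upward move at best, and it may stay unreadable if this assay again returns only a limit. For compound 4 the estimate is 1.8 10^-6 cm/s, with an expected range of 0.9 10^-6 cm/s to 4.5 10^-6 cm/s.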

Compound 4, apparent permeability: < 1.9 10^-6 cm/s
Compound 4 gave a limit, no number (the forecaster's own chance of this, stated with the estimate: 55%); the middle value lies beyond the limit too.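

In this assay compound 4 gives < 1.9 10^-6 cm/s, which is a limit and not a number. Among these compounds, compound 2, compound 3 and compound 4 each carry only a limit, so no step among them can be read. Still open, going by these compounds, is whether 2,4-difluorophenyl, 2-(trifluoromethyl)-1,3-thiazol-5-yl and 1,3-benzoxazol-2-yl differ at all in apparent permeability.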